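A few compounds are considered here, and "the series" means these few. Any claim that something is new, unique, unknown or untested is made for them only; others in the source may bear on it.

Measured so far in a functional assay on MCF7 cells (Homo sapiens) for antiproliferative activity, read by CCK-8 assay, with a stated time of 48 h; a higher number here means a weaker inhibitor, a lower number a stronger inhibitor:
compound 1 `O=c1c2ccccc2[se]n1-c1nnc(-c2ccc(Br)cc2)s1` gives 43300 nM
compound 2 `O=c1c2ccccc2[se]n1-c1nnc(-c2ccc(F)cc2)s1` gives 61500 nM
compound 3 `O=c1c2ccccc2[se]n1-c1nnc(-c2ccccc2Cl)s1` gives 4430 nM

Compound 3 stands lowest of the three numbers: the steps of a 9.8-fold lower number from compound 1 to compound 3 (0.99 log units; beyond the scatter) and a 14-fold lower number from compound 2 to compound 3 (1.14 log units; beyond the scatter) both lie beyond the scatter, whereas a 1.4-fold higher number from compound 1 to compound 2 (0.15 log units; within the scatter) stays within it. Compound 4 `Cc1cccc(-c2nnc(-n3[se]c4ccccc4c3=O)s2)c1` differs from compound 3 by 3-methylphenyl in place of 2-chlorophenyl on an aromatic carbon. Within the data shown here, no measured step exchanges 2-chlorophenyl for 3-methylphenyl, so the two steps into compound 3 are the only guide; they show that swapping the group on this carbon can move the number well beyond the scatter. Compound 4 is therefore expected to give a higher number than compound 3, with an estimated step of a 3.4-fold higher number from compound 3 to compound 4 (0.53 log units; beyond the scatter), landing between compound 3 and compounds 1 and 2. The estimate for compound 4 is 15000 nM, within 4000 nM to 60000 nM.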

Compound 4, half-maximal inhibitory concentration: 19900 nM
Compound 4: middle estimate off by 1.3-fold (0.12 log units), on the low side; the measured number falls inside the stated range.
By their numbers in this assay, from the lowest: compound 3; then compound 4; then compounds 1 and 2 (each within the scatter of the next).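

In this assay, 3-methylphenyl, which carries no halogen, still gives a lower number than either 4-substituted halophenyl group (a 3.1-fold lower number from compound 2 to compound 4 (0.49 log units; beyond the scatter); a 2.2-fold lower number from compound 1 to compound 4 (0.34 log units; beyond the scatter)). It does not match 2-chlorophenyl, however (a 4.5-fold higher number from compound 3 to compound 4 (0.65 log units; beyond the scatter)), so this position separates three levels among these four aryl groups. Nothing available explains these differences.

Still open, going by these compounds, is whether the change of group or the place of the substituent on the phenyl ring matters more, which 3-chlorophenyl and 2-methylphenyl would help to separate, and how an amine or a carboxylic acid on that ring would behave.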